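The source may report more compounds than this note shows. Statements on the series, on what has been measured and on what is new or still open speak of the compounds shown alone.

Within the data shown here, compound 1 `COc1ccc2cc([C@H](C)c3nnc(SCc4ccc(F)cc4)n3-c3ccc(F)cc3)ccc2c1` is one of three compounds measured in a functional assay on LNCaP cells (Homo sapiens) for cytotoxicity, read by MTT assay; a higher number here means a weaker inhibitor, a lower number a stronger inhibitor. In this assay compound 1 gives 104000 nM, the highest of the two plain numbers shown. Its nearest neighbour, compound 2 `COc1ccc2cc([C@H](C)c3nnc(SCc4ccc(C)cc4)n3-c3ccc(Cl)cc3)ccc2c1`, gives 52200 nM in this assay, a gap within the scatter, so the two cannot be ranked against each other. Compound 3 `COc1ccc2cc([C@H](C)c3nnc(SCc4ccc(C)cc4)n3-c3ccc(F)cc3)ccc2c1` returns only a limit of the assay in this assay, <= 400000 nM, and not a number. That limit leaves a step that the limit leaves unreadable from compound 1 to compound 3 and a step that the limit leaves unreadable from compound 2 to compound 3; the same fact is recorded as the limit of <= 400000 nM in this assay, at which 1 of the 3 values shown sits.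

Compound 4 `COc1ccc(CSc2nnc([C@@H](C)c3ccc4cc(OC)ccc4c3)n2-c2ccc(F)cc2)cc1` differs from compound 1 in a single spot: methoxy in place of fluoro on an aromatic carbon. Fluoro leaves and methoxy enters on an aromatic carbon of a six-membered aromatic ring of carbon only, para to a large group; seen one bond further out, a (4-fluorobenzyl)sulfanyl group becomes a (4-methoxybenzyl)sulfanyl group. Among the measured compounds shown here, no measured step tries a methoxy at this position, and the two measured steps both run into the limit and give no size. With nothing pointing in either direction, no step beyond the scatter is expected in this assay. Compound 4 is therefore estimated to give 100000 nM, in a range from 30000 nM to 350000 nM. That estimate means a step of a 1.0-fold lower number from compound 1 to compound 4 (0.02 log units; within the scatter), expected to stay within the scatter.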

Compound 4, half-maximal inhibitory concentration: 22800 nM
Estimate against measurement, compound 4: 4.4-fold (0.64 log units) above; measured number below the stated range.
By their numbers in this assay, from the lowest: compound 4; then compounds 2 and 1 (each within the scatter of the next).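

In this assay, among these compounds, putting methoxy in place of fluoro on this aromatic carbon gives a 4.6-fold lower number from compound 1 to compound 4 (0.66 log units; beyond the scatter), the first step at this position whose size can be read. The step is modest, but it shows that the position is not indifferent to what sits there: the change from a (4-fluorobenzyl)sulfanyl group to a (4-methoxybenzyl)sulfanyl group moves the number beyond the usual scatter of repeats, and towards a stronger inhibitor. The comparison of methoxy with methyl at this position stays closed, as do the earlier steps to compound 3, and none of them can be read because compound 3 returns only a limit of the assay: the limit of <= 400000 nM in this assay, at which 1 of the 4 values shown sits.

On these data alone, this leaves a single readable step at this position, so it remains open whether a longer chain such as ethoxy, a hydroxyl, an amine or a carboxylic acid in the same place would lower the number further, leave it unchanged or raise it. As far as these compounds go, it is also open whether methoxy would give a similar step with chloro in place of the fluoro on the other aromatic ring, the arrangement found in compound 2.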